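A few compounds are considered here, and "the series" means these few. Any claim that something is new, unique, unknown or untested is made for them only; others in the source may bear on it.

Compound 1 `COc1cccc(S(=O)(=O)Nc2ccc(-c3nc4ccccc4o3)cc2)c1` gives > 63000 nM in an assay on isolated protein for inhibition of malate dehydrogenase, mitochondrial (Sus scrofa), with stated times of 45 min and 30 min; on this read-out higher numbers stand for weaker inhibition and lower numbers for stronger inhibition.
Compound 2 `Cc1ccccc1S(=O)(=O)Nc1ccc(-c2nc3ccccc3o2)cc1` gives > 63000 nM in this assay.
Compound 3 `COc1ccc(Cl)cc1S(=O)(=O)Nc1ccc(-c2nc3ccccc3o2)cc1` is still to be measured in this assay.

Compound 1 reaches only a limit of the assay, > 63000 nM, and no number. Compound 2 likewise stops at a limit, > 63000 nM. Between them lies a step that the two limits leave unreadable from compound 1 to compound 2, so the exchange on the sulfonyl sulfur between these two cannot be sized. Compound 2 therefore stands at the limit of > 63000 nM in this assay, at which 2 of the 2 values shown sit, and nothing shown places it anywhere else.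

Compound 3 changes the same position: 5-chloro-2-methoxyphenyl in place of 2-methylphenyl on a sulfonyl sulfur. For the measured compounds named here, the only measured step that bears on this place is the one from compound 1 to compound 2, and its size is unreadable, so no direction and no size of step in this assay can be taken from the measured compounds; an estimate can only rest on where compound 2 itself stands. Compound 3 is accordingly expected to sit at about 100000 nM, within a range from 30000 nM to 400000 nM. This estimate for compound 3 means an expected step that the limit leaves unreadable from compound 2 to compound 3, and the measurement most likely returns only a limit again.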

Compound 3, half-maximal inhibitory concentration: > 63000 nM
Compound 3 was reported as a limit; the forecaster's own chance of this, stated with the estimate: 80%; the middle value does not contradict the limit.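

For the compounds shown here, compound 3 also reaches only a limit of the assay, > 63000 nM, so no step among compound 1, compound 2 and compound 3 can be read. All three stand together at: the limit of > 63000 nM in this assay, at which 3 of the 3 values shown sit.

The compounds shown leave open whether any group on the sulfonyl sulfur gives a measurable value in this assay.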